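Swapping the ring substituent on the amide of compound 3

The source may report more compounds than this note shows. Statements on the series, on what has been measured and on what is new or still open speak of the compounds shown alone.

Of the compounds shown here, three sharing one core have been measured in a functional assay on MIA PaCa-2 cells (Homo sapiens) for inhibition, read by MTT assay, with a stated time of 3 days; a higher number here means a weaker inhibitor, a lower number a stronger inhibitor. Compound 1 `CCN(CC)S(=O)(=O)c1ccc(S(=O)(=O)N2CCC[C@@H](C(=O)N[C@H]3CC[C@H](OC)CC3)C2)cc1` gives 2290 nM. Compound 2 `CCN(CC)S(=O)(=O)c1ccc(S(=O)(=O)N2CCC[C@@H](C(=O)NC3CCOCC3)C2)cc1` gives 1350 nM, and the step of a 1.7-fold lower number from compound 1 to compound 2 (0.23 log units; within the scatter) is too small to read as a real change. Compound 3 `CCN(CC)S(=O)(=O)c1ccc(S(=O)(=O)N2CCC[C@@H](C(=O)N3CCC(COC)CC3)C2)cc1` gives 50 nM, the lowest number of the three: the steps of a 46-fold lower number from compound 1 to compound 3 (1.66 log units; beyond the scatter) and a 27-fold lower number from compound 2 to compound 3 (1.43 log units; beyond the scatter) are both large and clearly beyond the scatter, and both replace an amide bearing a hydrogen with a fully substituted piperidin-1-yl amide.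

Compound 4 `CCN(CC)S(=O)(=O)c1ccc(S(=O)(=O)N2CCC[C@@H](C(=O)N3CCC(F)(F)CC3)C2)cc1` keeps that piperidin-1-yl amide and alters only its ring substituent: 4,4-difluoropiperidin-1-yl in place of 4-(methoxymethyl)piperidin-1-yl on a carbonyl carbon. Among the compounds with values here, no measured step touches this kind of exchange; the two large steps concern the amide nitrogen itself, which compound 4 leaves untouched. The expectation is therefore that compound 4 stays close to compound 3, with a step of a 2.0-fold higher number from compound 3 to compound 4 (0.30 log units; within the scatter) that may lie within the scatter or be modestly weakening. In this assay compound 4 is estimated at 100 nM, within a range from 30 nM to 350 nM.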

Compound 4, half-maximal inhibitory concentration: 19 nM
Compound 4: the middle estimate sits 5.3-fold (0.72 log units) above what was measured; measured number below the stated range.
By their numbers in this assay, from the lowest: compound 4; then compound 3; then compounds 2 and 1 (each within the scatter of the next).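

The ring substituent on the piperidin-1-yl amide is a position that responds to change: 4,4-difluoropiperidin-1-yl in place of 4-(methoxymethyl)piperidin-1-yl gives a 2.6-fold lower number from compound 3 to compound 4 (0.42 log units; beyond the scatter), a modest step, with the amide nitrogen left as it was. The oxygen of the methoxymethyl group is therefore not required for a low number in this series. The distance to the amides bearing a hydrogen also grows, with a 71-fold lower number from compound 2 to compound 4 (1.85 log units; beyond the scatter) and a 120-fold lower number from compound 1 to compound 4 (2.08 log units; beyond the scatter), both large.

No measurement available here explains why the difluoro ring gives the lower number. Going by these compounds, whether that result comes from the fluorine atoms or from losing the methoxymethyl chain stays open; a plain piperidin-1-yl amide and a 4-fluoropiperidin-1-yl amide would help separate the two.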